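This account rests on a few compounds, and the source may have more. Where it says the series, first, only, none or still open, it means among the compounds named here.

Measured compounds:
compound 1 `Cc1cc(S(=O)(=O)/N=C(\N)N/N=C/C#Cc2ccccc2)c(SCc2ccccc2)cc1Cl`, 5000 nM in a functional assay on HeLa cells (Homo sapiens) for antiproliferative activity, read by MTT assay, with a stated time of 72 h; on this read-out lower numbers stand for stronger inhibition and higher numbers for weaker inhibition
compound 2 `C/C(C#Cc1ccccc1)=N\N/C(N)=N/S(=O)(=O)c1cc(C)c(Cl)cc1SCc1ccccc1`, 6000 nM in this assay
compound 3 `Cc1cc(S(=O)(=O)/N=C(\N)N/N=C/C#Cc2ccccc2)c(SCc2ccccc2C(F)(F)F)cc1Cl`, 16000 nM in this assay

Compound 2 gives the second highest of the three numbers; compound 1 sits nearest, and the two differ only by a 1.2-fold higher number from compound 1 to compound 2 (0.08 log units; within the scatter), a change on an amine nitrogen that is within the scatter. Compound 3 gives the furthest number, and the step of a 3.2-fold higher number from compound 1 to compound 3 (0.51 log units; beyond the scatter), trifluoromethyl in place of hydrogen on an aromatic carbon of the benzyl ring, is modest but beyond the scatter.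

The unmeasured compound 4 `C/C(C#Cc1ccccc1)=N\N/C(N)=N/S(=O)(=O)c1cc(C)c(Cl)cc1SCc1cccc(C(F)(F)F)c1` differs from compound 2 by trifluoromethyl in place of hydrogen on an aromatic carbon. For the measured compounds named here, the one measured step that bears on this, a 3.2-fold higher number from compound 1 to compound 3 (0.51 log units; beyond the scatter), places the same kind of group on the same benzyl ring of the shared core, though at a different place. On that basis a modest rise in the number is expected for compound 4 in this assay, about a 2.5-fold higher number from compound 2 to compound 4 (0.40 log units; beyond the scatter). Compound 4 is therefore estimated at 15000 nM, in the range 6000 nM to 40000 nM.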

Compound 4, half-maximal inhibitory concentration: 18000 nM
The estimate for compound 4 lay 1.2-fold (0.08 log units) below the measured number; the measured number falls inside the stated range.
By their numbers in this assay, from the lowest: compounds 1 and 2 (each within the scatter of the next); then compounds 3 and 4 (each within the scatter of the next).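

In this assay, 3-(trifluoromethyl)benzyl in place of benzyl gives a 3.0-fold higher number from compound 2 to compound 4 (0.48 log units; beyond the scatter), so the rise in the number no longer rests on a single pair. The change reads alike on both cores, with the trifluoromethyl at a different place on the benzyl ring in each pair, and the two steps agree: the same change on two cores in this assay, a 3.2-fold higher number (0.51 log units; beyond the scatter) from compound 1 to compound 3 and a 3.0-fold higher number (0.48 log units; beyond the scatter) from compound 2 to compound 4, 1.1-fold (0.03 log units) apart, within the scatter of two such steps

Core and place of the group differ together across the two pairs, so this agreement cannot be assigned to either one alone.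

The compounds shown compare only hydrogen and trifluoromethyl on this ring; how a methoxy group, an amine or a carboxylic acid there would move the number remains open. Also open, as far as these compounds go, is how the two places on the benzyl ring compare on a single core.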